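Bromo in Place of Hydrogen on Compound 3

The source may hold more compounds than are shown below. What is called first, only, known or untested is meant among the compounds shown, and "the series" means these compounds.

In a functional assay on HCT-116 cells (Homo sapiens) for cytotoxicity, read by MTT assay, with a stated time of 72 h (a higher number here means a weaker inhibitor, a lower number a stronger inhibitor), compound 1 `O=S(=O)(c1ccccc1)c1nc2ccccc2nc1N1CCCC1` gives 24200 nM and compound 3 `O=S(=O)(c1ccccc1)c1nc2ccccc2nc1N1CCc2ccccc2C1` gives 18700 nM, two values within the scatter of each other. Compound 2 `COc1ccc(S(=O)(=O)c2nc3ccccc3nc2N2CCCC2)cc1` reads > 50000 nM, which is a limit of the assay and not a number. Compound 4 `O=S(=O)(c1ccc(Br)cc1)c1nc2ccccc2nc1N1CCc2ccccc2C1` carries bromo in place of hydrogen on an aromatic carbon, para to a large group: bromo in place of hydrogen on an aromatic carbon. For the measured compounds named here, only one measured step bears on this change, the replacement of hydrogen by methoxy on an aromatic carbon: an at least 2.0-fold higher number from compound 1 to compound 2 (0.31 log units; beyond the scatter). Bromo is a different group, so only a small rise is expected, and the estimated step is a 1.2-fold higher number from compound 3 to compound 4 (0.07 log units; within the scatter). Compound 4 is expected at 22000 nM, with an estimated range of 9000 nM to 50000 nM.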

Compound 4, half-maximal inhibitory concentration: > 50000 nM
Compound 4 gave a limit, no number (the forecaster's own chance of this, stated with the estimate: 20%); middle value at least 2.2-fold (0.35 log units) away from the limit.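

In this assay, for the compounds shown here, bromo in place of hydrogen para to a large group gives an at least 2.6-fold higher number from compound 3 to compound 4 (0.42 log units; beyond the scatter), a step beyond the scatter on a compound that held the lowest number so far. It joins an at least 2.0-fold higher number from compound 1 to compound 2 (0.31 log units; beyond the scatter), so both groups shown on this ring raise the number, on two different cores, and neither step goes against the other. Compound 4 stands at a limit and not a number, so its step gives only a minimum: the limit of > 50000 nM in this assay, at which 2 of the 4 values shown sit.

On these data alone, whether an amine or a carboxylic acid at this position would lower the number stays open. So does the size of the bromo step itself.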